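This account rests on a few compounds, and the source may have more. Where it says the series, first, only, none or still open, it means among the compounds named here.

The shared core carries an oxygen on a saturated carbon, and the three measured compounds differ only in what sits on that oxygen. Compound 1 `CCC(C)(O)CC(=O)O[C@H](CC=C(C)C)C1=CC(=O)c2c(O)ccc(O)c2C1=O` bears the 2-hydroxy-2-methylbutyl carbonyl there; in a functional assay on HeLa cells (Homo sapiens) for cytotoxicity, read by MTT assay (on this read-out higher numbers stand for weaker inhibition and lower numbers for stronger inhibition), compound 1 gives 25200 nM, the lowest of the two numbers obtained. Compound 3 `CC(C)=CC[C@@H](OC(=O)c1ccco1)C1=CC(=O)c2c(O)ccc(O)c2C1=O` gives 80300 nM in this assay, and the change from compound 1 reads as a 3.2-fold higher number from compound 1 to compound 3 (0.50 log units; beyond the scatter). Compound 2 `CC(C)=CC[C@@H](OC(=O)C1CCCCO1)C1=CC(=O)c2c(O)ccc(O)c2C1=O` reaches only a limit in this assay, > 100000 nM, so that the limit of > 100000 nM in this assay, at which 1 of the 3 values shown sits, applies to it. The remaining steps are an at least 3.9-fold higher number from compound 1 to compound 2 (0.59 log units; beyond the scatter) and an at least 1.2-fold lower number from compound 2 to compound 3 (0.09 log units; that floor lies within the scatter). Compound 4 `COCCO[C@H](CC=C(C)C)C1=CC(=O)c2c(O)ccc(O)c2C1=O` is not yet measured; it differs from compound 1 by 2-methoxyethyl in place of (2-hydroxy-2-methylbutyl)carbonyl on an oxygen on a saturated carbon. Within the data shown here, both measured departures from the 2-hydroxy-2-methylbutyl carbonyl, to oxan-2-yl and to furan-2-yl, gave higher numbers beyond the scatter, and no measured step covers an ether in place of the carbonyl, so a higher number is expected for compound 4 as well, about a 2.4-fold higher number from compound 1 to compound 4 (0.38 log units; beyond the scatter). Compound 4 is therefore estimated at 60000 nM in this assay, within a range of 15000 nM to 200000 nM.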

Compound 4, half-maximal inhibitory concentration: 62400 nM
For compound 4 the middle estimate is 1.0-fold (0.02 log units) below the measured one; the range from low to high includes it.
By their numbers in this assay, from the lowest: compound 1; then compounds 4 and 3 (each within the scatter of the next). At a limit, above all of these: compound 2.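

Replacing the ester with an ether at this oxygen still leaves a finite reading in this assay, with a 2.5-fold higher number from compound 1 to compound 4 (0.39 log units; beyond the scatter), so the carbonyl is not needed for a number to be obtained in this small set. Against the furan ester, the ether gives a 1.3-fold lower number from compound 3 to compound 4 (0.11 log units; within the scatter), so 2-methoxyethyl and (furan-2-yl)carbonyl cannot be told apart here, while compound 1 lies below both beyond the scatter. The comparison with the oxan-2-yl ester gives only a floor, an at least 1.6-fold lower number from compound 2 to compound 4 (0.20 log units; that floor lies within the scatter), and sets no order, since compound 2 stands at a limit, not a number: the limit of > 100000 nM in this assay, at which 1 of the 4 values shown sits.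

On these data alone, it remains open whether the hydroxyl of the (2-hydroxy-2-methylbutyl)carbonyl group goes with the lower number of compound 1. Also open, as far as these compounds go, is how a free hydroxyl on the saturated carbon, or an ether chain ending in an amine or a carboxylic acid, would read.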